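The source may hold more compounds than are shown below. What is called first, only, known or untested is meant among the compounds shown, and "the series" means these compounds.

The series keeps the shared core of compound 1 `COc1ccc(SCc2ccc(/C=C/C(=O)Nc3ccccc3N)cc2)cc1OC` and varies the aryl group that sits on a sulfur. In a functional assay on SMMC-7721 cells (Homo sapiens) for inhibition, read by CCK-8 assay, with a stated time of 72 h, tested at 8 uM (on this read-out lower numbers stand for less inhibition of growth and higher numbers for more inhibition of growth at the one concentration tested), compound 1 gives 44.6%. Compound 2 `Nc1ccccc1NC(=O)/C=C/c1ccc(CSc2ccc(F)cc2)cc1`, carrying 4-fluorophenyl on that sulfur, gives 15.4% in this assay, and compound 3 `Cc1cc(C)cc(SCc2ccc(/C=C/C(=O)Nc3ccccc3N)cc2)c1`, carrying 3,5-dimethylphenyl, gives 7.13%. Compound 3 stands lowest of the three numbers: one step, a number 8.3 percentage points lower from compound 2 to compound 3 (within the scatter), lies within the scatter, whereas the other, a number 37.5 percentage points lower from compound 1 to compound 3 (beyond the scatter), lies well beyond it.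

Compound 4 `Nc1ccccc1NC(=O)/C=C/c1ccc(CSc2cccc(F)c2)cc1` is yet to be measured. It differs from compound 3 in one place: 3-fluorophenyl in place of 3,5-dimethylphenyl on a sulfur. Among the measured compounds shown here, the only measured step that bears directly on this change is the one between the two smaller aryl groups, a number 8.3 percentage points lower from compound 2 to compound 3 (within the scatter), and that step is within the scatter. For the measured compounds named here, no measured pair separates 3-fluorophenyl from 4-fluorophenyl, so the position of the fluorine cannot be weighed. The large step of a number 37.5 percentage points lower from compound 1 to compound 3 (beyond the scatter) concerns 3,4-dimethoxyphenyl and does not transfer to the present change. The expected step for compound 4 is therefore a number 7.9 percentage points higher from compound 3 to compound 4 (within the scatter), at most a small rise and not clearly beyond the scatter. Compound 4 is estimated at 15%, with a range from 3% to 32%.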

Compound 4, percent growth inhibition at one concentration: 8.25%
Compound 4: middle estimate off by 6.8 percentage points, on the high side; the range from low to high includes it.
By their numbers in this assay, from the lowest: compounds 3, 4 and 2 (each within the scatter of the next); then compound 1.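

In this assay, 3-fluorophenyl in place of 3,5-dimethylphenyl on a sulfur gives a number 1.1 percentage points higher from compound 3 to compound 4 (within the scatter), and 3-fluorophenyl in place of 4-fluorophenyl gives a number 7.2 percentage points lower from compound 2 to compound 4 (within the scatter), so the position of the fluorine, which could not be weighed before, makes no readable difference between these two fluorophenyl groups. A third aryl group now reads with the low compounds, while the step to 3-fluorophenyl from 3,4-dimethoxyphenyl is a number 36.4 percentage points lower from compound 1 to compound 4 (beyond the scatter); among the four compounds, compound 1 alone stands apart, and none of them goes against this. No measurement at hand gives a reason for this separation.

The compounds shown leave open whether one methoxy group on the phenyl ring is enough to retain the higher reading of compound 1, or whether both methoxy groups of 3,4-dimethoxyphenyl are needed. From the compounds shown here alone, it also remains open how an aryl group carrying an amine, a hydroxyl or a carboxylic acid would read on the same sulfur, and whether the readings at this single concentration would keep their order at other concentrations.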